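A few compounds are considered here, and "the series" means these few. Any claim that something is new, unique, unknown or untested is made for them only; others in the source may bear on it.

Compounds measured so far:
- compound 1, `COc1ccc(N(C(=O)CN2C=CN(c3ccccc3)C(=O)[C@H](Cc3n[nH]c4ccccc34)C2=O)C(C)C)cc1`, 15.9 nM
- compound 2, `COc1ccc(N(C(=O)CN2C=CN(C3CCCCC3)C(=O)C(Cc3ccccc3)C2=O)C(C)C)cc1`, 31600 nM; > 30000 nM (2 entries)

Compound 1 was tested in a functional assay on CHO cells for agonist activity at Melanocyte-stimulating hormone receptor (Homo sapiens), read by a luciferase reporter, with a stated time of 4 h (a lower number here means that less compound is needed, a higher number that more compound is needed for the effect), and gives 15.9 nM. Among the compounds with values here, this is the only full number on hand; the second compound is reported differently. Compound 2, in this assay, gives 31600 nM; > 30000 nM (2 entries), reported as several entries rather than as a single number. Within the data shown here, no pair of compounds differing in one place has been measured, so no measured step is available to guide the next change.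

Compound 3 is `O=C1[C@@H](Cc2n[nH]c3ccccc23)C(=O)N(c2ccccc2)C=CN1CC(=O)N1CCCCc2ccccc21` and awaits measurement. Compared with compound 1 it carries a group of 11 heavy atoms (10 carbon, 1 nitrogen; one six-membered aromatic ring of carbon only, one seven-membered non-aromatic ring with 1 hetero atom) in place of a group of 12 heavy atoms (10 carbon, 1 nitrogen, 1 oxygen; one six-membered aromatic ring of carbon only), on a carbonyl carbon. Among the measured compounds shown here, since no measured step covers a change of this kind, the expectation rests on compound 1 alone, and a moderate loss, possibly beyond the scatter, is anticipated. Compound 3 is expected to give 60 nM in this assay, with a likely range from 10 nM to 400 nM, corresponding to an estimated step of a 3.8-fold higher number from compound 1 to compound 3 (0.58 log units; beyond the scatter).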

Compound 3, half-maximal effective concentration: 1.59 nM
Compound 3: middle estimate off by 38-fold (1.58 log units), on the high side; measured number outside the range, below it.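

In this assay, putting the group with one seven-membered non-aromatic ring with 1 hetero atom in place of isopropyl(4-methoxyphenyl)amino gives a 10-fold lower number from compound 1 to compound 3 (1.00 log units; beyond the scatter) at this place on a carbonyl carbon. Within the data shown here, this is the first measured step at this place, and it shows that isopropyl(4-methoxyphenyl)amino can leave without any loss, since the entering group, which keeps one six-membered aromatic ring of carbon only but has no hydrogen-bond acceptor, gives the lower number. No measurement shown gives a property of either group that bears on this step.

The compounds shown leave open whether a five-membered or six-membered ring with one nitrogen would hold this number in place of the seven-membered ring. They also leave open how a methoxy group or a fluorine on the aromatic ring of the entering group would shift it.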